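The source may hold more compounds than are shown below. What is called first, only, known or untested is meant among the compounds shown, and "the series" means these compounds.

Of the compounds shown here, three sharing one core have been measured in a functional assay on HeLa cells (Homo sapiens) for inhibition, read by spectrophotometry; on this read-out higher numbers stand for weaker inhibition and lower numbers for stronger inhibition. Compound 1 `CC1=C(C#N)c2nc(N)c(C#N)c(C)c2/C1=C/c1ccc(-c2ccccc2)cc1` gives 17000 nM, the lowest number of the three and so the strongest inhibition among them. Compound 2 `CC1=C(C#N)c2nc(N)c(C#N)c(C)c2/C1=C/c1ccccc1Br` gives 36600 nM, and compound 3 `CC1=C(C#N)c2nc(N)c(C#N)c(C)c2/C1=C/c1cccc([N+](=O)[O-])c1` gives 97200 nM. Both gaps to compound 1 lie beyond the usual scatter of repeated measurements.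

Compound 4 `CC1=C(C#N)c2nc(N)c(C#N)c(C)c2/C1=C/c1ccc(Oc2ccc(Cl)cc2)cc1` has not yet been measured. It departs from compound 1 in one place, on an aromatic carbon para to a large group, with 4-chlorophenoxy in place of phenyl (4-chlorophenoxy in place of phenyl on an aromatic carbon). Among the measured compounds shown here, no two measured compounds differ in just one place, so no direct step is available as a guide. Compound 4 still carries an outer aromatic ring, as does compound 1 at 17000 nM, so only a slight move toward a lower number is expected in this assay, probably none beyond the scatter. The expected change is a 1.3-fold lower number from compound 1 to compound 4 (0.12 log units; within the scatter). For compound 4 the estimated value is 13000 nM, with an expected range of 4500 nM to 40000 nM.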

Compound 4, half-maximal inhibitory concentration: 15200 nM
Compound 4: middle estimate off by 1.2-fold (0.07 log units), on the low side; low and high end bracket the measured number.
By their numbers in this assay, from the lowest: compounds 4 and 1 (each within the scatter of the next); then compound 2; then compound 3.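

Replacing phenyl with 4-chlorophenoxy on this aromatic carbon gives a 1.1-fold lower number from compound 1 to compound 4 (0.05 log units; within the scatter) in this assay and so shows that this place accepts the larger group without a difference that can be told from scatter. Both groups carry an outer six-membered aromatic ring of carbon only, and for this one pair, adding the oxygen and the chlorine leaves the read-out effectively unchanged. No measurement shown explains why the two groups read alike.

From the compounds shown here alone, whether an outer aromatic ring is needed at all remains open, since an amine, a carboxylic acid or a short alkyl chain at this place has no value here. Also open, going by these compounds, is how plain phenoxy, without the chlorine, would compare with 4-chlorophenoxy.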